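This account rests on a few compounds, and the source may have more. Where it says the series, first, only, none or still open, it means among the compounds named here.

Of the compounds shown here, two of the shared core have been measured in a functional assay on HeLa cells for antagonist activity at 5-hydroxytryptamine receptor 6 (Homo sapiens), read by cAMP accumulation and immunoassay; on this read-out higher numbers stand for weaker inhibition and lower numbers for stronger inhibition. Compound 1 `O=S(=O)(c1ccccc1F)c1cn(C2CCNC2)c2ncccc12` gives 50 nM. Compound 2 `CN1CCC(n2cc(S(=O)(=O)c3ccc(F)cc3)c3cccnc32)C1` gives 213 nM, the higher of the two numbers, and its gap to compound 1 lies beyond the scatter. Compound 3 `CN1CCC(n2cc(S(=O)(=O)c3cccc(Cl)c3)c3cccnc32)C1` is not yet measured; it carries 3-chlorophenyl in place of 4-fluorophenyl on a sulfonyl sulfur. Among the compounds with values here, no measured pair shows this change, so a step of only modest size is expected, if any, leaning toward stronger inhibition yet likely within the scatter, as a 1.6-fold lower number from compound 2 to compound 3 (0.21 log units; within the scatter). Compound 3 is therefore estimated at 130 nM, ranging from 40 nM to 400 nM.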

Compound 3, half-maximal inhibitory concentration: 142 nM
Estimate against measurement, compound 3: 1.1-fold (0.04 log units) below; the range from low to high includes it.
By their numbers in this assay, from the lowest: compound 1; then compounds 3 and 2 (each within the scatter of the next).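

In this assay, putting 3-chlorophenyl in place of 4-fluorophenyl on a sulfonyl sulfur gives a 1.5-fold lower number from compound 2 to compound 3 (0.18 log units; within the scatter), so this first single-place comparison does not separate compound 2 from compound 3. This position therefore accepts a change of both the halogen and its place on the ring without a step beyond the scatter. No independent measurement bears on this result.

Going by these compounds, whether a 3-fluorophenyl or a 4-chlorophenyl would behave the same stays open, so the two parts of the change remain unseparated. Also open, on these data alone, is what a methoxyphenyl or an aminophenyl would give here.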